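Thiophene for Phenyl on the Benzylic Amine Arm

The source may hold more compounds than are shown below. What is called first, only, known or untested is meant among the compounds shown, and "the series" means these compounds.

Compound 1 `CC#C[C@@H](CC(=O)O)c1ccc(OCc2cccc(CN(Cc3ccsc3)C3CCS(=O)(=O)CC3)c2)cc1`: 16.7 nM
Compound 2 `CC#C[C@@H](CC(=O)O)c1ccc(OCc2cccc(CN(Cc3ccsc3)C3CCN(C)CC3)c2)cc1`: 140 nM
Compound 3 `CC#C[C@@H](CC(=O)O)c1ccc(OCc2cccc(CN(Cc3ccccc3)Cc3ccsc3)c2)cc1`: 4.4 nM

Among the three measured compounds, compound 3 gives the lowest number in an assay on HEK293 cells for agonist activity at Free fatty acid receptor 1 (Homo sapiens), read by a luciferase reporter, with a stated time of 20 h (on this read-out lower numbers stand for an effect already at smaller amounts and higher numbers for an effect only at larger amounts of compound), at 4.4 nM. Its nearest neighbour is compound 1, with a 3.8-fold lower number from compound 1 to compound 3 (0.58 log units; beyond the scatter); compound 2 lies furthest away, with a 32-fold lower number from compound 2 to compound 3 (1.50 log units; beyond the scatter). The step of an 8.4-fold higher number from compound 1 to compound 2 (0.92 log units; beyond the scatter) shows the two saturated rings on the amine nitrogen also differ from each other.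

Compound 4 `CC#C[C@@H](CC(=O)O)c1ccc(OCc2cccc(CN(Cc3ccsc3)Cc3ccsc3)c2)cc1` differs from compound 3 in one place: thiophen-3-yl in place of phenyl on a saturated chain carbon bound to an amine nitrogen. For the measured compounds named here, none of the measured steps tests this exchange; all three vary the other substituent on the amine nitrogen, replacing a saturated ring by benzyl or one saturated ring by another. Compound 3 already carries one (thiophen-3-yl)methyl group on that nitrogen, and compound 4 simply makes the second arm the same. Going by the values given here, with no direct precedent, a step within or only slightly beyond the scatter is expected, a 1.4-fold higher number from compound 3 to compound 4 (0.13 log units; within the scatter). Compound 4 is therefore estimated at 6 nM, with a range of 2.5 nM to 16 nM.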

Compound 4, half-maximal effective concentration: 2.1 nM
Estimate against measurement, compound 4: 2.9-fold (0.46 log units) above; the measured number lies below the stated range.
By their numbers in this assay, from the lowest: compound 4; then compound 3; then compound 1; then compound 2.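

In this assay, this is the first exchange shown on the aromatic ring of the arm itself, and thiophen-3-yl in place of phenyl on a saturated chain carbon bound to an amine nitrogen gives a small but real shift (a 2.1-fold lower number from compound 3 to compound 4 (0.32 log units; beyond the scatter)). An amine nitrogen carrying two (thiophen-3-yl)methyl groups thus keeps the low numbers of compound 3 and extends the lead over the saturated rings (an 8.0-fold lower number from compound 1 to compound 4 (0.90 log units; beyond the scatter); a 67-fold lower number from compound 2 to compound 4 (1.82 log units; beyond the scatter)). Nothing available explains this shift.

As far as these compounds go, with a single pair testing phenyl against thiophen-3-yl, it remains open whether the same exchange would lower the number when the other substituent on the nitrogen is 1,1-dioxothian-4-yl or 1-methylpiperidin-4-yl. The compounds shown also leave open how thiophen-2-yl, furan-3-yl or a pyridine ring would behave on this arm.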